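The compounds below may be only part of what the source reports. "The series", "measured", "known", "first", "only" and "open" are said of these compounds alone.

Measured so far in an assay on HEK293 cells for positive allosteric modulation of metabotropic glutamate receptor 5 (Homo sapiens), read by FLIPR, with a stated time of 1 h; a higher number here means that more compound is needed for the effect, a lower number that less compound is needed:
compound 1, `O=C1NCCc2nc(C#Cc3cccc(F)c3)sc21`: 290 nM
compound 2, `Fc1cccc(C#Cc2nc3c(s2)CN(C2CCOC2)CC3)c1`: > 10000 nM, a limit of the assay rather than a number
compound 3, `C(#Cc1nc2c(s1)CN(C1CCCCC1)CC2)c1ccccc1`: > 10000 nM, again a limit rather than a number

Compound 3 thus stands on no number at all: it shares (the limit of > 10000 nM in this assay, at which 2 of the 3 values shown sit), and only compound 1 has a measured concentration among the three. Nothing between pairs of measured compounds that differ in a single place is available, so no step size can be read off directly.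

Compound 4, `O=C(C1CCCC1)N1CCc2nc(C#Cc3ccccc3)sc2C1`, arises from compound 3 by a change on an amine nitrogen in a ring: cyclopentylcarbonyl in place of cyclohexyl on an amine nitrogen in a ring

Among the measured compounds, the only one that gave a number in this assay is compound 1 with 290 nM, and like compound 4 it carries a carbonyl next to the ring nitrogen rather than a plain alkyl group. On that slender basis a gain in potency is expected for compound 4, a step in the direction of less compound being needed, well beyond the scatter, estimated as an at least 14-fold lower number from compound 3 to compound 4 (1.15 log units; beyond the scatter). Compound 4 is accordingly estimated at 700 nM, within a range of 120 nM to 5000 nM, with a real chance that it again gives only a limit.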

Compound 4, half-maximal effective concentration: 19 nM
Estimate against measurement, compound 4: 37-fold (1.57 log units) above; measured number below the stated range.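

On an amine nitrogen in a ring, cyclopentylcarbonyl in place of cyclohexyl gives an at least 520-fold lower number from compound 3 to compound 4 (2.72 log units; beyond the scatter) in this assay, the only step among these compounds that can be read at all, and it shows that the group on this nitrogen can decide whether the compound gives a measured number. The change alters two things at once, adding a carbonyl and going from a six-membered to a five-membered ring, so this step alone cannot be divided between them. Compound 3 gives > 10000 nM, which is a limit of the assay and not a number, so the step marks only the least the change achieves: the limit of > 10000 nM in this assay, at which 2 of the 4 values shown sit.

From the compounds shown here alone, it remains open whether the carbonyl or the ring size carries the gain, a question that cyclohexylcarbonyl or plain cyclopentyl on the same nitrogen would help to settle. Going by these compounds, it is also open how much of the ring in cyclopentylcarbonyl is needed, and whether a simple acetyl or a longer chain ending in a carbonyl would serve at this position as well.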